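Amino for carboxy on the benzyl ring of compound 3

The compounds below may be only part of what the source reports. "The series", "measured", "known", "first", "only" and "open" are said of these compounds alone.

Measured so far:
compound 1, `O=C1NC(=O)c2c(NCc3ccccc3[N+](=O)[O-])cccc21`, in an assay for inhibition of Indoleamine 2,3-dioxygenase 1 (Homo sapiens), with stated times of 10 min and 60 min (on this read-out lower numbers stand for stronger inhibition and higher numbers for weaker inhibition), gives > 100000 nM, a limit.
compound 2, `O=[N+]([O-])c1cccc(CNc2cc(Br)cc3[nH]ncc23)c1`, in this assay gives 7950 nM.
compound 3, `O=C(O)c1cccc(CNc2cc(C(F)(F)F)cc3[nH]ncc23)c1`, in this assay gives > 100000 nM, a limit.

Among the measured compounds shown here, compound 3 therefore stands at the limit of > 100000 nM in this assay, at which 2 of the 3 values shown sit; the only numerical value among the three belongs to compound 2. For the measured compounds named here, no step between two measured compounds is available, so the change from compound 3 to compound 4 is untested.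

Compound 4, `Nc1cccc(CNc2cc(C(F)(F)F)cc3[nH]ncc23)c1`, differs from compound 3 by amino in place of carboxy on an aromatic carbon, meta to a large group. Starting from a limit, the step from compound 3 to compound 4 is expected to be an at least 3.3-fold lower number from compound 3 to compound 4 (0.52 log units; beyond the scatter), toward stronger inhibition and beyond the scatter, though a further limit remains possible. Compound 4 is estimated at 30000 nM, with a range from 5000 nM to 100000 nM.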

Compound 4, half-maximal inhibitory concentration: > 100000 nM
Compound 4: a limit, no number (the forecaster's own chance of this, stated with the estimate: 40%); at least 3.3-fold (0.52 log units) between middle value and limit.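

Compound 3 and compound 4 both give limits, so the step between them cannot be read: the limit of > 100000 nM in this assay, at which 3 of the 4 values shown sit.

The compounds shown leave open how amino and carboxy on the benzyl ring compare in inhibition.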